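This account rests on a few compounds, and the source may have more. Where it says the series, first, only, none or still open, it means among the compounds named here.

Working notes on the pyridyl urea series.

Compound 3 `O=C(Nc1ccncc1)Nc1ccccc1C(F)(F)F` is the reference point. In a functional assay on the whole organism with Mus musculus as the target, in the maximal electroshock model, with a stated time of 30 min (on this read-out lower numbers stand for an effect already at smaller amounts and higher numbers for an effect only at larger amounts of compound), compound 3 gives 100 mg/kg. Compound 1 `O=C(Nc1ccncc1)Nc1ccccc1Br` gives 100 mg/kg, and compound 2 `O=C(Nc1ccncc1)Nc1ccccc1F` gives 100 mg/kg. The three measured steps are all flat: no change at the digits printed from compound 1 to compound 2 (within the scatter), no change at the digits printed from compound 1 to compound 3 (within the scatter) and no change at the digits printed from compound 2 to compound 3 (within the scatter). Among the measured compounds shown here, compound 3 therefore stands level with compounds 1 and 2 on the numbers so far.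

The next compound, compound 4 `N#Cc1ccccc1NC(=O)Nc1ccncc1`, differs from compound 3 at the same aromatic carbon that has carried the three previous substituents: cyano in place of trifluoromethyl on an aromatic carbon.

All three steps measured so far concern swaps of the group on this carbon, and none of them moved the read-out beyond the scatter. Nothing in the data distinguishes the cyano group from the three groups already tried at this place. The expected step is accordingly flat, no change at the digits printed from compound 3 to compound 4 (within the scatter), with no direction favoured. For compound 4 the estimate in this assay is 100 mg/kg, with a range from 50 mg/kg to 200 mg/kg.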

Compound 4, minimum effective dose: > 300 mg/kg
Compound 4 ended at the assay's limit (the forecaster's own chance of this, stated with the estimate: 25%); middle value at least 3.0-fold (0.47 log units) from the limit.
By their numbers in this assay, from the lowest: compounds 1, 2 and 3 (each within the scatter of the next). At a limit, above all of these: compound 4.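

In this assay compound 4 gives > 300 mg/kg, which is a limit of the assay and not a number. This aromatic carbon is therefore not indifferent to its substituent: cyano moves the read-out where the other swaps did not, with an at least 3.0-fold higher number from compound 3 to compound 4 (0.47 log units; beyond the scatter), an at least 3.0-fold higher number from compound 2 to compound 4 (0.47 log units; beyond the scatter) and an at least 3.0-fold higher number from compound 1 to compound 4 (0.47 log units; beyond the scatter). Among the four groups shown here, the split is cyano on one side and bromo, fluoro and trifluoromethyl, level with one another at the digits printed, on the other.

From the compounds shown here alone, how far compound 4 lies from the other three stays unresolved, and the steps are bounded on one side only: the limit of > 300 mg/kg in this assay, at which 1 of the 4 values shown sits. Also open is whether an amine, a carboxylic acid or a methoxy group on this carbon would stay level with compound 3 or part from it as cyano does.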